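Clearance notes on the fused-core series, compound 2 to 4

The source may hold more compounds than are shown below. What is called first, only, known or untested is meant among the compounds shown, and "the series" means these compounds.

Measured so far:
- compound 1, `Cc1ncccc1-c1cnc(NCc2c(F)ccc3c2CCO3)c2nn(CC#N)c(=O)n12`: 151 mL.min-1.g-1
- compound 2, `O=C1c2ccccc2CN1c1cnc(NCc2c(F)ccc3c2CCO3)n2cnnc12`: 13 mL.min-1.g-1
- compound 3, `Cc1ncccc1-c1cnc(NCc2c(F)ccc3c2CCO3)n2c(=O)[nH]nc12`: 36 mL.min-1.g-1

All three were run in an ADME assay on microsomes from liver (Homo sapiens) for metabolic stability, read by LC-MS, using NADPH, with stated times of 5 min and 30 min, tested at 1 uM; a lower number here means slower removal, a higher number faster removal of the compound. Compound 2 stands lowest of the three numbers; its gap to compound 3 and its gap to compound 1 are both beyond the usual scatter, so compound 2 is the slowest-cleared compound of those measured.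

The next compound, compound 4, `CN(c1cccnc1)c1cnc(NCc2c(F)ccc3c2CCO3)n2cnnc12`, has not yet been measured in this assay. It keeps the shared core and the amine-linked side chain of compound 2 and differs in one place:

a group of 8 heavy atoms (6 carbon, 2 nitrogen; one six-membered aromatic ring with 1 hetero atom) in place of a group of 10 heavy atoms (8 carbon, 1 nitrogen, 1 oxygen; one five-membered non-aromatic ring with 1 hetero atom, one six-membered aromatic ring of carbon only), on an aromatic carbon

The group that leaves carries the only double bond outside aromatic rings in that part of the molecule; the methyl(pyridin-3-yl)amino group that enters brings one more hydrogen-bond acceptor and fewer heavy atoms. Among the measured compounds shown here, no step between measured compounds covers this change, so the expectation rests on the spread of the three values: compound 3, which also carries a pyridine on the same aromatic carbon, sits above compound 2 by more than the scatter.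

For compound 4 the number in this assay is expected to rise, with a step of a 3.5-fold higher number from compound 2 to compound 4 (0.54 log units; beyond the scatter), placing it near compound 3. The estimate for compound 4 is 45 mL.min-1.g-1, within a range of 15 mL.min-1.g-1 to 130 mL.min-1.g-1.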

Compound 4, intrinsic clearance in microsomes: 80 mL.min-1.g-1
Estimate against measurement, compound 4: 1.8-fold (0.25 log units) below; the range from low to high includes it.
By their numbers in this assay, from the lowest: compound 2; then compound 3; then compounds 4 and 1 (each within the scatter of the next).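

In this assay, among the compounds shown here, the number depends strongly on what the aromatic carbon of the six-membered aromatic ring with 2 nitrogen carries, with a 6.2-fold higher number from compound 2 to compound 4 (0.79 log units; beyond the scatter) as the only step here that isolates a change in one place. For the compounds shown here, the earlier compounds offered no such pair, so this is the first direct reading at this position. The change replaces a group holding a five-membered non-aromatic ring, a six-membered aromatic ring of carbon only and a double bond outside aromatic rings with methyl(pyridin-3-yl)amino, and no measurement in hand ties the rise to any one of these differences or gives a reason for it.

The compounds shown leave open whether the pyridine ring or the methyl on the linking nitrogen accounts for the step, and a morpholine or a plain dimethylamino group on the same aromatic carbon would help separate those two parts. Also open, going by these compounds, is whether the same exchange would move the number in the same direction on the core of compound 3.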